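The compounds below may be only part of what the source reports. "The series", "measured", "known", "first", "only" and "open" are said of these compounds alone.

Measured so far:
Compound 1 `Nc1ncnc2c1c(Oc1cccc(Cl)c1)nn2CC1CCOCC1` gives 0.233 h in an ADME assay on microsomes from liver (Rattus norvegicus) for metabolic stability, read by LC-MS, tested at 1 uM; on this read-out lower numbers stand for a shorter-lived compound and higher numbers for a longer-lived compound
Compound 2 `Cc1cccc(Oc2nn(C(C)(C)C)c3ncnc(N)c23)c1` gives 0.07 h in this assay

Of the two compounds measured, compound 1 has the higher number, and its gap to compound 2 lies beyond the usual scatter of repeated measurements, so compound 1 is the longer-lived of the pair. Compound 3 `CN1CCC(Cn2nc(Oc3cccc(Cl)c3)c3c(N)ncnc32)CC1` has not yet been measured. It differs from compound 1 in one place: 1-methylpiperidin-4-yl in place of oxan-4-yl on a saturated chain carbon bound to an aromatic nitrogen. The two compounds share the same core and the same substituted aromatic ether; only the saturated ring at the end of the short chain changes, from one with an oxygen atom to one with a nitrogen atom carrying a methyl group.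

Among the compounds with values here, no measured pair shows this change, so the size of the step from compound 1 to compound 3 in this assay cannot be read off from the data. The expectation here is a step of no clear direction and of a size within the scatter, a 1.2-fold lower number from compound 1 to compound 3 (0.07 log units; within the scatter). Compound 3 is therefore expected to give about 0.2 h, with a plausible range from 0.07 h to 0.6 h.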

Compound 3, half-life: > 1 h
Compound 3: no number, only a limit (the forecaster's own chance of this, stated with the estimate: 5%); at least 5.0-fold (0.69 log units) between middle value and limit.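

In this assay, compound 3 gives > 1 h, which is a limit of the assay and not a number. The earlier pair, compound 1 and compound 2, differs in more than one place and so could not show what the saturated ring alone does, whereas here a single exchange of oxan-4-yl for 1-methylpiperidin-4-yl, on a saturated chain carbon bound to an aromatic nitrogen, gives an at least 4.2-fold higher number from compound 1 to compound 3 (0.63 log units; beyond the scatter), so this ring at the end of the short chain has a clear bearing on the half-life read-out, with the rest of the molecule unchanged. On these data alone, the step can be given only as a minimum, and its true size stays unknown because the value of compound 3 is cut off by the assay: the limit of > 1 h in this assay, at which 1 of the 3 values shown sits.

As far as these compounds go, what stays open is which part of the new ring goes with the longer half-life, the ring nitrogen or the methyl group on it, a question that a piperidin-4-yl ring without the methyl, or an all-carbon cyclohexyl ring, would speak to. Also open, from the compounds shown here alone, is whether the same exchange has a similar effect when the chlorophenyl ether of the shared core is replaced by another group, such as a methylphenyl ether.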